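Chlorophenyl Triazole Sulfonamides Tested for Antiproliferative Activity

This account rests on a few compounds, and the source may have more. Where it says the series, first, only, none or still open, it means among the compounds named here.

Four compounds sharing a sulfonamide-linked uracil core are considered here. Compound 1 `O=c1[nH]cc(S(=O)(=O)Nc2cccc(-c3cn(-c4ccccc4Cl)nn3)c2)c(=O)[nH]1` and compound 2 `O=c1[nH]cc(S(=O)(=O)Nc2cccc(-c3cn(-c4cccc(Cl)c4)nn3)c2)c(=O)[nH]1` carry the triazole on one position of the central ring, compound 3 `O=c1[nH]cc(S(=O)(=O)Nc2ccc(-c3cn(-c4ccccc4Cl)nn3)cc2)c(=O)[nH]1` and compound 4 `O=c1[nH]cc(S(=O)(=O)Nc2ccc(-c3cn(-c4cccc(Cl)c4)nn3)cc2)c(=O)[nH]1` on another; how the two cores differ is not broken down here. In a functional assay on HepG2 cells (Homo sapiens) for antiproliferative activity, read by MTT assay, with a stated time of 24 h (on this read-out higher numbers stand for weaker inhibition and lower numbers for stronger inhibition), compound 1 gives 4030 nM and compound 2 gives 4200 nM. The change between them, (3-chlorophenyl in place of 2-chlorophenyl on an aromatic nitrogen), produced a 1.0-fold higher number from compound 1 to compound 2 (0.02 log units; within the scatter). In this assay compound 3 gives 2230 nM, the lowest of the three numbers, though its gaps to compound 1 and to compound 2 both lie within the scatter, so no order among them is claimed.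

Compound 4 has not yet been measured. It differs from compound 3 by 3-chlorophenyl in place of 2-chlorophenyl on an aromatic nitrogen, the same change that turned compound 1 into compound 2. Because that earlier change gave a 1.0-fold higher number from compound 1 to compound 2 (0.02 log units; within the scatter), the step from compound 3 to compound 4 in this assay is expected to be similarly small, a 1.0-fold higher number from compound 3 to compound 4 (0.01 log units; within the scatter). Compound 4 is therefore estimated at 2300 nM in this assay, most likely between 1200 nM and 4600 nM.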

Compound 4, half-maximal inhibitory concentration: 2020 nM
The estimate for compound 4 lay 1.1-fold (0.06 log units) above the measured number; measured number inside the range.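

Once compound 4 is measured, the exchange of 2-chlorophenyl for 3-chlorophenyl on the aromatic nitrogen gives a 1.1-fold lower number from compound 3 to compound 4 (0.04 log units; within the scatter) in this assay. Set beside the earlier step, this shows that the change carried over between the two cores in this series as a step too small to read, with no difference between the cores that stands out: the same change on two cores in this assay, a 1.0-fold higher number (0.02 log units; within the scatter) from compound 1 to compound 2 and a 1.1-fold lower number (0.04 log units; within the scatter) from compound 3 to compound 4, 1.2-fold (0.06 log units) apart, within the scatter of two such steps. This holds only for these two pairs in this one cell assay; it does not show that the change would stay as small on a further core or in another assay, and steps of this size give no direction for the change on either core.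

The compounds shown leave open how the number responds when the chlorine itself is exchanged for another group, such as a methoxy group, an amine or a carboxylic acid. They also leave open whether such a group, unlike the chlorine, would behave alike on the two cores.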